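A Second Aryl Swap on the Same Carbonyl Carbon

This account rests on a few compounds, and the source may have more. Where it says the series, first, only, none or still open, it means among the compounds named here.

Of the compounds shown here, two have so far been measured in a functional assay on NCI-H460 cells (Homo sapiens) for cytotoxicity, read by sulforhodamine B assay, with a stated time of 48 h, tested at 0.01 uM; on this read-out lower numbers stand for a stronger effect and higher numbers for a weaker effect at the one concentration tested. Compound 2 `COc1ccc(C(=O)/C=C/c2cc(-c3cc(OC)c(OC)c(OC)c3)n[nH]2)cc1OC` gives 103%. Compound 1 `COc1cc(-c2cc(/C=C/C(=O)c3ccc(Cl)c(Cl)c3)[nH]n2)cc(OC)c1OC` gives 105%. Among the compounds with values here, compound 2 therefore shows the lowest of the two numbers, yet its only neighbour, compound 1, sits within the usual scatter of it, so the two compounds cannot be told apart on this read-out. Within the data shown here, the one step seen so far, a number 2 percentage points lower from compound 1 to compound 2 (within the scatter), exchanged one aryl group for another on the carbonyl carbon and made no difference beyond the scatter.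

Compound 3 `COc1cc(-c2cc(/C=C/C(=O)c3ccc(F)c(F)c3)[nH]n2)cc(OC)c1OC` changes the same position once more: 3,4-difluorophenyl in place of 3,4-dimethoxyphenyl on a carbonyl carbon. Among the measured compounds shown here, the step from compound 1 to compound 2 is the only measured step that bears on this change, since it also replaced the aryl group on the carbonyl carbon, and it was small. Compound 3, like compound 1, carries two halogens on that aryl group, and compound 1 gave 105%. The step of a number 1 percentage points higher from compound 2 to compound 3 (within the scatter) is therefore expected to stay within the scatter. Compound 3 is estimated at 104%, with a range from 93% to 115%.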

Compound 3, a percentage reported as activity, at one concentration (the size of the read-out at that concentration, not a potency): 106%
For compound 3 the middle estimate is 2 percentage points below the measured one; the range from low to high includes it.
By their numbers in this assay, from the lowest: compounds 2, 1 and 3 (each within the scatter of the next).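

With compound 3, a third aryl group now sits on the carbonyl carbon, and this assay gives two new comparisons: a number 3 percentage points higher from compound 2 to compound 3 (within the scatter) on replacing 3,4-dimethoxyphenyl with 3,4-difluorophenyl, and a number 1 percentage points higher from compound 1 to compound 3 (within the scatter) on replacing 3,4-dichlorophenyl with 3,4-difluorophenyl. Within the data shown here, both steps lie within the scatter, even though the first removes a group with hydrogen-bond acceptors and brings in one with none, so at this single concentration the read-out cannot separate the three aryl groups. No further data are available to explain this lack of separation.

As far as these compounds go, all three groups are phenyl rings carrying the same two-part substitution pattern, so it remains open whether a different kind of group on the carbonyl carbon, such as a phenyl bearing an amine or a carboxylic acid, would stand apart from them. From the compounds shown here alone, it also remains open whether these three compounds would separate at other concentrations, since one concentration shows only the size of the read-out there and says nothing about potency.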